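The compounds below may be only part of what the source reports. "The series", "measured", "known", "first", "only" and "open" are said of these compounds alone.

Compound 1 `O=c1cc(/C=N\Nc2ccc([N+](=O)[O-])cc2)c2ccc(OCc3ccccc3)cc2o1` stands at the bottom of the numbers shown: in a functional assay, read by spectrophotometry, with a stated time of 5 min (on this read-out lower numbers stand for stronger inhibition and higher numbers for weaker inhibition), compound 1 gives > 2000000 nM, which is a limit of the assay rather than a measured number (the limit of > 2000000 nM in this assay, at which 1 of the 3 values shown sits). Two measured changes start from it. Compound 2 `O=c1cc(/C=N\Nc2ccc([N+](=O)[O-])cc2[N+](=O)[O-])c2ccc(OCc3ccccc3)cc2o1` adds a nitro group on an aromatic carbon and gives 181000 nM in this assay, a step of an at least 11-fold lower number from compound 1 to compound 2 (1.04 log units; beyond the scatter). Compound 3 `O=c1cc(/C=N\Nc2ccc([N+](=O)[O-])cc2)c2c(OCc3ccccc3)cc(OCc3ccccc3)cc2o1` adds a benzyloxy group on an aromatic carbon and gives 419000 nM, a step of an at least 4.7-fold lower number from compound 1 to compound 3 (0.67 log units; beyond the scatter). Compound 4 `O=c1cc(/C=N\c2ccccc2O)c2ccc(OCc3ccccc3)cc2o1` differs from compound 1 in another way, (2-hydroxyphenyl in place of (4-nitrophenyl)amino on a double-bonded nitrogen), so neither measured step touches the part that changes here. Both steps show that compound 1 sits where an alteration can only lower the number or leave it at the limit, but they give no guidance on this particular swap. For compound 4 the expected value is 600000 nM, between 100000 nM and 2000000 nM. The estimated step from compound 1 is an at least 3.3-fold lower number from compound 1 to compound 4 (0.52 log units; beyond the scatter), with a real chance that the assay again reports only a limit.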

Compound 4, half-maximal inhibitory concentration: 469000 nM
Beside the measured number, compound 4's estimate is 1.3-fold (0.11 log units) above it; the measured number falls inside the stated range.
By their numbers in this assay, from the lowest: compound 2; then compounds 3 and 4 (each within the scatter of the next). At a limit, above all of these: compound 1.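

In this assay, among the compounds shown here, putting 2-hydroxyphenyl in place of (4-nitrophenyl)amino on a double-bonded nitrogen gives an at least 4.2-fold lower number from compound 1 to compound 4 (0.62 log units; beyond the scatter), so this part of the molecule, which the earlier steps left untouched, also affects the read-out. On this core, the (4-nitrophenyl)amino group is therefore not needed for a measurable number. Compound 1 stands at a limit, so this step gives only a bound on the true change: the limit of > 2000000 nM in this assay, at which 1 of the 4 values shown sits.

This single swap removes the nitro group and the amino link and brings in a hydroxyl group all at once, so the compounds shown cannot say which of these changes matters. They also leave open how a plain phenyl or a methoxyphenyl group would read on this same nitrogen.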